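From pyridin-3-yl to thiophen-2-yl at the assay limit

The source may hold more compounds than are shown below. What is called first, only, known or untested is meant among the compounds shown, and "the series" means these compounds.

Compound 3 `CC(C)(C)Sc1c(CC(C)(C)C(=O)O)n(Cc2ccc(Cl)cc2)c2ccc(OCc3cccnc3)cc12` sits at the edge of what a functional assay (blood) for inhibition, with Homo sapiens as the target (on this read-out lower numbers stand for stronger inhibition and higher numbers for weaker inhibition), can report. Compound 3 gives > 3000 nM, which is a limit and not a number. Compound 1 `Cc1nc2ccc(COc3ccc4c(c3)c(SC(C)(C)C)c(CC(C)(C)C(=O)O)n4Cc3ccc(Cl)cc3)cc2s1` gives > 3000 nM, which is also a limit. Among the measured compounds shown here, compound 2 `CC(C)(C)Sc1c(CC(C)(C)C(=O)O)n(Cc2ccc(Cl)cc2)c2ccc(OCc3nc4ccccc4o3)cc12` gives 2500 nM, the only actual number so far.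

Compound 4 `CC(C)(C)Sc1c(CC(C)(C)C(=O)O)n(Cc2ccc(Cl)cc2)c2ccc(OCc3cccs3)cc12` carries thiophen-2-yl in place of pyridin-3-yl on a saturated chain carbon bound to an oxygen on an aromatic ring. Three measured steps changed this same group. Two give only a floor within the scatter: an at least 1.2-fold lower number from compound 1 to compound 2 (0.07 log units; that floor lies within the scatter) and an at least 1.2-fold higher number from compound 2 to compound 3 (0.07 log units; that floor lies within the scatter). The third, a step that the two limits leave unreadable from compound 1 to compound 3, cannot be read. None therefore shows a change here moving the read-out beyond the scatter, so no clear step in either direction is expected. The expected change is a number no higher from compound 3 to compound 4 (the limit leaves the size open). Compound 4 is estimated at 3000 nM, with an expected range of 1500 nM to 6000 nM. Another limit is also quite possible, given (the limit of > 3000 nM in this assay, at which 2 of the 3 values shown sit).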

Compound 4, half-maximal inhibitory concentration: > 3000 nM
Compound 4 gave a limit, no number (the forecaster's own chance of this, stated with the estimate: 55%); the middle value sits exactly at the limit.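

Placing a five-membered ring, thiophen-2-yl, on the saturated chain carbon bound to an oxygen on an aromatic ring still gives no readable number in this assay, since compound 4 also ends at a limit. Among the compounds shown here, the one readable comparison is an at least 1.2-fold higher number from compound 2 to compound 4 (0.07 log units; that floor lies within the scatter), which does not separate the two compounds. The steps to compound 4 from compound 1 and from compound 3 cannot be read, and the new result adds one more compound to those at the ceiling: the limit of > 3000 nM in this assay, at which 3 of the 4 values shown sit.

Going by these compounds, how far compound 1, compound 3 and compound 4 lie past that limit stays unknown, so no order among their groups can be given. Also open, on these data alone, is whether a non-aromatic group in this place, such as an amine or a longer alkyl chain, would give a number clearly apart from that of compound 2.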